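From Cyclohexyl Ketone to Ethyl Urea on a Shared Core

A few compounds are considered here, and "the series" means these few. Any claim that something is new, unique, unknown or untested is made for them only; others in the source may bear on it.

Measured compounds:
compound 1, `Cc1nn(C(=O)C2CCC2)c(N)c1-c1ccc(Cl)c(Cl)c1`: > 100000 nM
compound 2, `Cc1nn(C(=O)C2CCCCC2)c(N)c1-c1ccc(Cl)c(Cl)c1`: > 100000 nM

In an assay on Sf9 cells for inhibition of inhibitor of nuclear factor kappa-B kinase subunit epsilon (Homo sapiens), read by ADP-Glo, with a stated time of 60 min (a lower number here means a stronger inhibitor, a higher number a weaker inhibitor), compound 1 gives > 100000 nM, which is a limit of the assay and not a number. In this assay compound 2 likewise gives only a limit, > 100000 nM. The step that the two limits leave unreadable from compound 1 to compound 2 therefore has no readable size because both values sit at the limit of > 100000 nM in this assay, at which 2 of the 2 values shown sit. Where compound 2 stands can thus be said only this far: it shows no measurable inhibition up to the limit, and the one other value shown is a limit as well.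

Compound 3, `CCNC(=O)n1nc(C)c(-c2ccc(Cl)c(Cl)c2)c1N`, differs from compound 2 in one place: ethylamino in place of cyclohexyl on a carbonyl carbon. Within the data shown here, the only measured step, from compound 1 to compound 2, changes the same carbonyl substituent and is unreadable, so it gives no direction and no size for the present change; it shows only that two ring substituents on that carbonyl both leave the compound inactive. Compound 3 is therefore expected to remain near the limit in this assay, with an estimated step of a number no higher from compound 2 to compound 3 (the limit leaves the size open). The estimate for compound 3 in this assay is 100000 nM, within 30000 nM to 300000 nM.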

Compound 3, half-maximal inhibitory concentration: > 100000 nM
Compound 3: only a limit was reported; the forecaster's own chance of this, stated with the estimate: 80%; the middle value sits exactly at the limit.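

The steps among compound 1, compound 2 and compound 3 cannot be read, because in this assay each compound gives only a limit of the assay and not a number: the limit of > 100000 nM in this assay, at which 3 of the 3 values shown sit.

The compounds shown leave open whether any substituent on this carbonyl carbon of the shared core gives measurable inhibition, and how the cyclobutyl, cyclohexyl and ethylamino compounds would rank.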